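Benzoxazole ether series: amine swap at the chain end

The source may hold more compounds than are shown below. What is called first, only, known or untested is meant among the compounds shown, and "the series" means these compounds.

Measured so far:
- compound 1 `Clc1ccc(Oc2ccc3nc(-c4ccc(OCCCN5CCCCC5)cc4)oc3c2)cc1`: 2.2%
- compound 2 `CCN(CC)CCCOc1ccc(-c2nc3ccc(Oc4ccc(C(C)(C)C)cc4)cc3o2)cc1`: "not active" (no number reported)

In an assay on isolated protein for inhibition of advanced glycosylation end product-specific receptor (Homo sapiens), read by FRET, with stated times of 30 min and 1 h, tested at 4 uM (on this read-out higher numbers stand for more inhibition at the one concentration tested (going by the name of the read-out) and lower numbers for less inhibition), compound 1 gives 2.2%, and compound 2 gives "not active" (no number reported), so compound 2 stands without a single number, only a report of no activity. Compound 3 `CC(C)(C)c1ccc(Oc2ccc3nc(-c4ccc(OCCCN5CCCCC5)cc4)oc3c2)cc1` is not yet measured. It differs from compound 2 by piperidin-1-yl in place of diethylamino on a saturated chain carbon, three bonds along the chain from an oxygen on an aromatic ring; the rest of the structure is unchanged. Given compound 1 at 2.2% and compound 2 reported as inactive, no step beyond the usual scatter is expected from compound 2 to compound 3 in this assay. Compound 3 is expected to give 3%, within 0% to 12%, with a fair chance the assay again reports no number.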

Compound 3, a percentage reported as inhibition, at one concentration (the size of the read-out at that concentration, not a potency): "not active" (no number reported)
Compound 3: no number reported, and the estimate cannot be compared.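

In this assay compound 2 gives "not active" (no number reported) and compound 3 gives "not active" (no number reported), so no step can be read between them. No evidence on hand bears on this result. Still open, from the compounds shown here alone, is whether piperidin-1-yl in place of diethylamino changes inhibition where a number can be read.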